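This account rests on a few compounds, and the source may have more. Where it says the series, first, only, none or still open, it means among the compounds named here.

Measured compounds:
compound 1, `CCCCc1ccc(NS(=O)(=O)c2ccc(N3CCNC3=O)cc2)cc1`, 610 nM
compound 2, `O=C1NCCN1c1ccc(S(=O)(=O)Nc2ccc(I)cc2)cc1`, 650 nM
compound 3, `CC(C)(C)c1ccc(NS(=O)(=O)c2ccc(N3CCNC3=O)cc2)cc1`, > 1000 nM (a limit)

The three compounds share one core and differ only in the group carried on the sulfonamide nitrogen. In a functional assay on HT-29 cells (Homo sapiens) for antiproliferative activity, read by sulforhodamine B assay, with a stated time of 48 h (on this read-out lower numbers stand for stronger inhibition and higher numbers for weaker inhibition), compound 1 gives 610 nM and compound 2 gives 650 nM. Compound 3 gives > 1000 nM in this assay, which is a limit of the assay rather than a number (the limit of > 1000 nM in this assay, at which 1 of the 3 values shown sits). Compound 2 holds the higher of the two plain numbers, yet a 1.1-fold higher number from compound 1 to compound 2 (0.03 log units; within the scatter), so the two cannot be told apart. The steps of an at least 1.6-fold higher number from compound 1 to compound 3 (0.21 log units; that floor lies within the scatter) and an at least 1.5-fold higher number from compound 2 to compound 3 (0.18 log units; that floor lies within the scatter) likewise leave the floor of their size within the scatter. Compound 4, `Cc1ccc(C)c(NS(=O)(=O)c2ccc(N3CCNC3=O)cc2)c1`, carries 2,5-dimethylphenyl in place of 4-iodophenyl on a sulfonamide nitrogen. For the measured compounds named here, no measured step covers this exact change; the three measured steps at the same place all stayed within the scatter, so no step beyond the scatter is expected, with some chance that the assay again returns only a limit. Compound 4 is therefore estimated at 800 nM, between 400 nM and 2000 nM, which means an expected step of a 1.2-fold higher number from compound 2 to compound 4 (0.09 log units; within the scatter) that should stay within the scatter.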

Compound 4, half-maximal inhibitory concentration: 46 nM
The estimate for compound 4 lay 17-fold (1.24 log units) above the measured number; measured number outside the range, below it.
By their numbers in this assay, from the lowest: compound 4; then compounds 1 and 2 (each within the scatter of the next). At a limit, above all of these: compound 3.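

In this assay, the change from 4-iodophenyl to 2,5-dimethylphenyl on the sulfonamide nitrogen gives a 14-fold lower number from compound 2 to compound 4 (1.15 log units; beyond the scatter), the first step at this place shown to exceed the scatter. The earlier compounds shown here suggested a flat response here, whereas this result shows that the group on the sulfonamide nitrogen can strongly shift the antiproliferative read-out, even though both groups have one six-membered aromatic ring of carbon only, no hydrogen-bond donors or acceptors and no net charge. Nothing among the data offered here explains the size of this step.

The compounds shown leave open whether both methyl groups of the 2,5-dimethylphenyl group are needed, as no methylphenyl compound appears among them. They also leave open whether 2,5-dichlorophenyl or 2,5-dimethoxyphenyl would behave in the same way at this place.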